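Working notes: double-bond geometry from compound 3 to compound 4

The source may hold more compounds than are shown below. What is called first, only, known or untested is meant among the compounds shown, and "the series" means these compounds.

Compound 1 `C=CCSS/C=C\C[S+]([O-])CCC` gives 17000 nM as measured
Compound 2 `C=CCSS/C=C\C[S+]([O-])CCCO` gives 22800 nM as measured
Compound 3 `C=CCSS/C=C/C[S+]([O-])CCCOCc1ccc(OC)cc1` gives 23500 nM as measured

All three values come from a functional assay on cells (Fibroblast) for antiproliferative activity (a higher number here means a weaker inhibitor, a lower number a stronger inhibitor), and lie within the scatter of one another, so compound 3 cannot be ranked against compound 1 or compound 2. Compound 4 `C=CCSS/C=C\C[S+]([O-])CCCOCc1ccc(OC)cc1` has not yet been measured in this assay and is the geometric partner of compound 3. The structural change is as follows: the two compounds have the same atoms and bonds; at least one stereo element is drawn with a configuration in one of them and without one in the other: 1 of 2 stereo elements differ; a double bond is drawn E in compound 3 and Z in compound 4 and no group enters or leaves.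

Within the data shown here, no measured pair isolates this change. Among the measured compounds shown here, the only measured step is a 1.3-fold higher number from compound 1 to compound 2 (0.13 log units; within the scatter) and it concerns a hydroxy in place of hydrogen on a saturated chain carbon, not the double bond. The nearest indirect evidence is a comparison across geometries. Compound 2 gives 22800 nM with this double bond drawn Z, and compound 3 gives 23500 nM with it drawn E, but these two compounds also differ elsewhere. Their values lie within the scatter of each other.

The estimated change is a 1.1-fold lower number from compound 3 to compound 4 (0.03 log units; within the scatter) and so no step beyond the scatter is expected. For compound 4 the expected value is 22000 nM with an estimated range from 12000 nM to 38000 nM in this series.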

Compound 4, half-maximal inhibitory concentration: 21700 nM
Compound 4: the middle estimate sits 1.0-fold (0.01 log units) above what was measured; low and high end bracket the measured number.
By their numbers in this assay, from the lowest: compounds 1, 4, 2 and 3 (each within the scatter of the next).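

In this assay, among these compounds, this pair is the first to isolate the double-bond geometry, and the change is a 1.1-fold lower number from compound 3 to compound 4 (0.03 log units; within the scatter). The earlier comparison of compound 2 with compound 3 also spanned the two geometries, but those compounds differ elsewhere as well, whereas here the geometry is the only difference, and with this chain end the E and Z forms cannot be told apart in this read-out. One qualification applies to the reading of this pair: the fact that one of compounds 3 and 4 is drawn with a defined configuration and the other without, at the place where they differ

From the compounds shown here alone, it remains open whether the geometry stays equally without visible effect when the chain ends in another group, such as the hydroxy of compound 2, an amine or a carboxylic acid. Also open, going by these compounds, is whether a longer chain in place of the allyl group would give a step beyond the scatter in this assay, with either double-bond geometry.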